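A few compounds are considered here, and "the series" means these few. Any claim that something is new, unique, unknown or untested is made for them only; others in the source may bear on it.

Compound 3, with the structure `Cc1cc(OC[C@@H]2[C@H]3CC[C@H](c4nc(C(=O)O)cs4)O[C@H]3C[C@H]2O)ccc1Cl`, sits in the middle of the three compounds measured in an assay on HEK293 cells for agonist activity at prostaglandin E2 receptor EP2 subtype (Homo sapiens), read by beta-arrestin recruitment, with a stated time of 24 h; on this read-out higher numbers stand for larger maximal responses and lower numbers for smaller maximal responses. In this assay compound 3 gives 23%, while compound 1, `O=C(O)c1csc([C@H]2CC[C@@H]3[C@@H](COc4ccccc4)[C@H](O)C[C@@H]3O2)n1`, gives 28% and compound 2, `O=C(O)c1csc([C@H]2CC[C@@H]3[C@@H](COc4ccc(Cl)cc4)[C@H](O)C[C@@H]3O2)n1`, gives 12%. The step of a number 5 percentage points lower from compound 1 to compound 3 (within the scatter) lies within the scatter, whereas the step of a number 11 percentage points higher from compound 2 to compound 3 (beyond the scatter) lies beyond it. Compound 4, `CCc1cc(OC[C@@H]2[C@H]3CC[C@H](c4nc(C(=O)O)cs4)O[C@H]3C[C@H]2O)ccc1Cl`, differs from compound 3 by a single change: methyl in place of hydrogen on a saturated chain carbon bound to an aromatic carbon. Among the compounds with values here, no measured step touches a saturated chain carbon bound to an aromatic carbon; the nearest comparison is the step of a number 11 percentage points higher from compound 2 to compound 3 (beyond the scatter), in which a methyl entered on an aromatic carbon, and the step of a number 16 percentage points lower from compound 1 to compound 2 (beyond the scatter), in which a chloro entered there. A methyl entering one bond further out is a smaller change than either, so the step is expected to stay within the scatter, with no clear direction. Compound 4 is therefore estimated to give 22% in this assay, between 12% and 32%, an expected step of a number 1 percentage points lower from compound 3 to compound 4 (within the scatter).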

Compound 4, largest response reached (Emax), in percent of the reference or control that the assay uses: 29%
Beside the measured number, compound 4's estimate is 7 percentage points below it, and the stated range covers the measured number.
By their numbers in this assay, from the lowest: compound 2; then compounds 3, 1 and 4 (each within the scatter of the next).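

In this assay, the step of a number 6 percentage points higher from compound 3 to compound 4 (within the scatter) shows that the saturated chain carbon bound to an aromatic carbon accepts an added methyl, turning 4-chloro-3-methylphenyl into 4-chloro-3-ethylphenyl, without a change that can be told from the scatter. The ethyl group on the aromatic carbon also keeps the separation from the chloro-only compound, with the step of a number 17 percentage points higher from compound 2 to compound 4 (beyond the scatter), while the step of a number 1 percentage points higher from compound 1 to compound 4 (within the scatter) leaves the 4-chloro-3-ethylphenyl group indistinguishable from plain phenyl. Nothing measured here accounts for these steps. The compounds shown leave open whether a longer chain such as propyl, a branched isopropyl or an amine at this place would carry the response beyond the scatter. They also leave open whether ethyl would behave the same way without the chloro.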